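The source may report more compounds than this note shows. Statements on the series, on what has been measured and on what is new or still open speak of the compounds shown alone.

Measured so far:
- compound 1 `CN1[C@@H]2c3[nH]c4ccccc4c3C[C@H]1[C@H](C#N)N1[C@@H](CNC(=O)c3ccc(Cl)cc3)c3[nH]c4ccccc4c3C[C@@H]21`: 230 nM
- compound 2 `CN1[C@@H]2c3[nH]c4ccccc4c3C[C@H]1[C@H](C#N)N1[C@@H](CNC(=O)c3ccc4ccccc4n3)c3[nH]c4ccccc4c3C[C@@H]21`: 60 nM

In a functional assay on A2780 cells (Homo sapiens) for cytotoxicity, read by MTT assay, with a stated time of 72 h (on this read-out lower numbers stand for stronger inhibition and higher numbers for weaker inhibition), compound 2 gives 60 nM, the lowest of the two numbers recorded, and compound 1 gives 230 nM. Among the measured compounds shown here, the one step measured, from compound 1 to compound 2, is a 3.8-fold lower number from compound 1 to compound 2 (0.58 log units; beyond the scatter); it exchanged one aromatic group for another on the carbonyl carbon of the amide.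

Compound 3 `CN1[C@@H]2c3[nH]c4ccccc4c3C[C@H]1[C@H](C#N)N1[C@@H](CNC(=O)c3cc4ccccc4o3)c3[nH]c4ccccc4c3C[C@@H]21` differs from compound 2 in that same place: 1-benzofuran-2-yl in place of quinolin-2-yl on a carbonyl carbon. For the measured compounds named here, both groups carry one hydrogen-bond acceptor in a fused aromatic pair, so the step from compound 1 to compound 2 is the only guide, and it shows that swapping the group on that carbonyl carbon moves the number by a modest amount. A step of that order, here expected toward a somewhat higher number, is a 1.5-fold higher number from compound 2 to compound 3 (0.18 log units; within the scatter). Compound 3 is therefore estimated at 90 nM, with a range from 35 nM to 250 nM.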

Compound 3, half-maximal inhibitory concentration: 230 nM
Compound 3: the middle estimate sits 2.6-fold (0.41 log units) below what was measured; measured number inside the range.
By their numbers in this assay, from the lowest: compound 2; then compounds 1 and 3 (each within the scatter of the next).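

In this assay, the lower number of compound 2 does not extend to every fused aromatic pair on this carbonyl carbon: a 3.8-fold higher number from compound 2 to compound 3 (0.58 log units; beyond the scatter), although quinolin-2-yl and 1-benzofuran-2-yl each count one hydrogen-bond acceptor. The other comparison shows no change at the digits printed from compound 1 to compound 3 (within the scatter), so 1-benzofuran-2-yl and 4-chlorophenyl cannot be told apart here, and among these three groups only quinolin-2-yl stands out. Nothing measured here explains why quinolin-2-yl and 1-benzofuran-2-yl give different numbers.

The compounds shown leave open how naphthalen-2-yl or 1H-indol-2-yl would behave on this carbonyl carbon, and so whether the ring nitrogen of quinolin-2-yl is what sets compound 2 apart. They also leave open whether the same order would hold in other cell lines.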